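The source may report more compounds than this note shows. Statements on the series, on what has been measured and on what is new or still open speak of the compounds shown alone.

Working notes on the series. In a functional assay on MIA PaCa-2 cells (Homo sapiens) for inhibition, read by MTT assay, with a stated time of 48 h, tested at 10 uM (a higher number here means more inhibition of growth at the concentration tested, a lower number less inhibition of growth), compound 1 `Cc1cc(=O)c2c(O)c(CN3CCC(c4ccccc4)CC3)c(O)c([C@H]3CCN(C)C[C@H]3O)c2o1` gives 16% and compound 2 `Cc1oc2c([C@H]3CCN(C)C[C@H]3O)c(O)cc(O)c2c(=O)c1C(O)c1ccc(F)c(Br)c1` gives 9% while compound 3 `Cc1oc2c([C@H]3CCN(C)C[C@H]3O)c(O)cc(O)c2c(=O)c1C(O)c1c(F)cccc1Cl` gives 41% and stands highest of the three numbers, beyond the scatter of both others. Compound 4 `Cc1oc2c([C@H]3CCN(C)C[C@H]3O)c(O)cc(O)c2c(=O)c1C(O)c1ccc(F)cc1` carries 4-fluorophenyl in place of 2-chloro-6-fluorophenyl on a saturated chain carbon bound to an aromatic carbon and an oxygen on a saturated carbon. Going by the values given here, compound 2 also lacks the 2-chloro-6-fluorophenyl group, and the only measured step at this place is large (a number 32 percentage points higher from compound 2 to compound 3 (beyond the scatter)). A large fall in this assay is therefore expected (a number 24 percentage points lower from compound 3 to compound 4 (beyond the scatter)). Compound 4 is estimated at 17% (expected range 5% to 35%).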

Compound 4, percent growth inhibition at one concentration: 17%
Compound 4: middle estimate and measured number agree at the digits printed; the range from low to high includes it.
By their numbers in this assay, from the lowest: compounds 2, 1 and 4 (each within the scatter of the next); then compound 3.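

In this assay, 4-fluorophenyl in place of 2-chloro-6-fluorophenyl gives a number 24 percentage points lower from compound 3 to compound 4 (beyond the scatter), so two different groups at this place, in compound 2 and compound 4, now stand short of 2-chloro-6-fluorophenyl. Hydrogen in place of bromo on an aromatic carbon gives a number 8 percentage points higher from compound 2 to compound 4 (within the scatter), so this assay does not separate these two compounds.

Open, from the compounds shown here alone, is whether the chloro, the fluoro or both carry the value of compound 3, and how an amine or a carboxylic acid in place of the chloro would read. Nothing on hand explains these steps.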